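Swapping the Bicyclic Amine for Piperidine: Plasma Binding

The compounds below may be only part of what the source reports. "The series", "measured", "known", "first", "only" and "open" are said of these compounds alone.

Of the compounds shown here, three built on one shared core have been tested in an ADME assay on a cell-free system (plasma, Homo sapiens); on this read-out lower numbers stand for a smaller free fraction and higher numbers for a larger free fraction. Among the compounds with values here, compound 1 `CC(=O)Nc1cc(-c2ccc(N(C)C(=O)c3c(C)cccc3F)c(N3CC4CC4C3)c2)n(C(C)C)n1` gives 0.011, and compound 3 `CC(=O)Nc1cc(-c2ccc(N(C)C(=O)c3c(Cl)cccc3Cl)c(N3CC4CC4C3)c2)n(C(C)C)n1` gives 0.004; the only single-point step among the measured compounds, a 2.8-fold lower number from compound 1 to compound 3 (0.44 log units; beyond the scatter), concerns the ring attached to the carbonyl carbon. Compound 2 `CC(=O)Nc1cc(-c2cnc(N(C)C(=O)c3c(F)cccc3Cl)c(N3CC4CC4C3)c2)n(C(C)C)n1` gives 0.056, the highest of the three numbers; compound 1 stands nearest to it and compound 3 furthest, and both gaps lie beyond the scatter.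

Compound 4 `CC(=O)Nc1cc(-c2cnc(N(C)C(=O)c3c(F)cccc3Cl)c(N3CCCCC3)c2)n(C(C)C)n1` has not yet been measured. It differs from compound 2 in one place: a group of 6 heavy atoms (5 carbon, 1 nitrogen; one six-membered non-aromatic ring with 1 hetero atom) in place of a group of 6 heavy atoms (5 carbon, 1 nitrogen; one three-membered non-aromatic ring of carbon only, one five-membered non-aromatic ring with 1 hetero atom), on an aromatic carbon. Within the data shown here, the one measured step alters a different part of the molecule, so it says nothing about how this exchange of one amine ring for another will behave in this assay. No measured step bears on the change, and the data give no reason to expect the number to move one way or the other beyond the scatter. The plainest expectation is therefore a value close to that of compound 2. Compound 4 is expected to give about 0.045, within 0.02 to 0.1, an expected step of a 1.2-fold lower number from compound 2 to compound 4 (0.09 log units; within the scatter) that stays within the usual scatter.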

Compound 4, unbound fraction: 0.076
Compound 4: middle estimate off by 1.7-fold (0.23 log units), on the low side; the range from low to high includes it.
By their numbers in this assay, from the lowest: compound 3; then compound 1; then compounds 2 and 4 (each within the scatter of the next).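

Exchanging the bicyclic amine for piperidin-1-yl gives a 1.4-fold higher number from compound 2 to compound 4 (0.13 log units; within the scatter) in this assay, so the two compounds cannot be told apart on this read-out. Within the data shown here, this is the first look at this position, on an aromatic carbon of a six-membered aromatic ring with 1 nitrogen. Among these compounds, the only earlier step concerned the ring on the carbonyl carbon; here, one amine ring can replace the other without a change beyond the scatter, at least in this one pair. The two groups match in heavy atoms, hydrogen-bond donors, hydrogen-bond acceptors and net charge, but no measurement here explains why the read-out holds steady when the ring system is exchanged.

One pair cannot show whether piperidin-1-yl would behave the same way with the 2,6-dichlorophenyl group of compound 3 or the 2-fluoro-6-methylphenyl group of compound 1. It also leaves open how this assay would respond at this position to a morpholine ring, which brings an oxygen atom into the ring, or to an open-chain dimethylamino group.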